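This account rests on a few compounds, and the source may have more. Where it says the series, first, only, none or still open, it means among the compounds named here.

In a functional assay on DU-145 cells (Homo sapiens) for inhibition, read by trypan blue exclusion, with a stated time of 96 h; a higher number here means a weaker inhibitor of growth, a lower number a stronger inhibitor of growth:
- compound 1 `COc1ccc(/C=C(/Sc2ccc(Br)cc2)C(=O)c2ccc(Br)cc2)cc1`: 25000 nM
- compound 2 `COc1ccc(/C=C(/Sc2ccc(C)cc2)C(=O)c2ccc(Br)cc2)cc1`: 50000 nM

Within the data shown here, compound 2 cannot be separated from the only other measured compound: a 2.0-fold higher number from compound 1 to compound 2 (0.30 log units; within the scatter). Compound 3 `COc1ccc(/C=C(/SCc2ccc(Cl)cc2)C(=O)c2ccc(Br)cc2)cc1` differs from compound 2 by 4-chlorobenzyl in place of 4-methylphenyl on a sulfur. Among the measured compounds shown here, no measured step covers this exchange, so that single small step is only a weak guide. No shift beyond the scatter is expected in this assay, and the direction is open. The expected change is a 1.7-fold lower number from compound 2 to compound 3 (0.22 log units; within the scatter). For compound 3 the estimate is 30000 nM, with an expected range of 8000 nM to 80000 nM.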

Compound 3, concentration for 50% growth inhibition: 10000 nM
Compound 3: the middle estimate sits 3.0-fold (0.48 log units) above what was measured, and the stated range covers the measured number.
By their numbers in this assay, from the lowest: compound 3; then compounds 1 and 2 (each within the scatter of the next).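

On the sulfur, 4-chlorobenzyl in place of 4-methylphenyl gives the first shift beyond the scatter in this assay: a 5.0-fold lower number from compound 2 to compound 3 (0.70 log units; beyond the scatter). Set against 4-bromophenyl on the same sulfur, the change also reads beyond the scatter, a 2.5-fold lower number from compound 1 to compound 3 (0.40 log units; beyond the scatter), so this position responds to the exchange, though only modestly. No evidence bears on this result.

Still open, from the compounds shown here alone, is whether the shift follows the benzyl form or its chlorine. Plain benzyl, a longer phenylalkyl chain or an amine-bearing chain on the sulfur would test this.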